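Quinolinedione series: amine swap from compound 2 to compound 4

A few compounds are considered here, and "the series" means these few. Any claim that something is new, unique, unknown or untested is made for them only; others in the source may bear on it.

Three members of the series have been run in a functional assay on NCI60 cells (Homo sapiens) for cytotoxicity; a lower number here means a stronger inhibitor of growth, a higher number a weaker inhibitor of growth. Compound 1 `O=C1C=C(N2CC2)C(=O)c2nc(-c3ccccc3)ccc21` gives 85.1 nM in this assay, and compound 3 `Cc1ccc2c(n1)C(=O)C=C(N1CC1)C2=O` gives 513 nM. Compound 2 `O=C1C(N2CCCC2)=CC(=O)c2nc(-c3ccccc3)ccc21` gives 44700 nM in this assay, the highest number of the three; its gap to compound 3 and its larger gap to compound 1 both lie beyond the scatter, so compound 2 is the weakest growth inhibitor measured so far.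

Compound 4 `COCCCNC1=CC(=O)c2nc(-c3ccccc3)ccc2C1=O` has not been measured. Relative to compound 2 the change is (3-methoxypropyl)amino in place of pyrrolidin-1-yl on a double-bonded ring carbon. Among the measured compounds shown here, no measured pair shows this exact change, so the step can only be expected, not read off. The expectation is that the number will move downward, by a step of moderate size beyond the scatter, toward the region occupied by compound 3 without reaching compound 1. The estimated step from compound 2 to compound 4 is an 8.9-fold lower number from compound 2 to compound 4 (0.95 log units; beyond the scatter). For compound 4 the estimate in this assay is 5000 nM, with a range from 800 nM to 30000 nM.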

Compound 4, concentration for 50% growth inhibition: 3550 nM
Compound 4: the middle estimate sits 1.4-fold (0.15 log units) above what was measured; measured number inside the range.
By their numbers in this assay, from the lowest: compound 1; then compound 3; then compound 4; then compound 2.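

In this assay, the series now has its first step at a single place: a 13-fold lower number from compound 2 to compound 4 (1.10 log units; beyond the scatter). On this double-bonded ring carbon the growth-inhibition read-out therefore responds to the amine, and the ring of pyrrolidin-1-yl is not required for the lower number, since the open (3-methoxypropyl)amino chain gives a number beyond the scatter from that of compound 2. The change swaps a ring for a chain, adds a hydrogen-bond donor and brings in an ether oxygen all at once, and nothing available separates these contributions or explains the step.

Whether the methoxy oxygen matters would show in a plain propylamino or butylamino chain. Morpholin-4-yl would test the oxygen with the ring kept, and 3-hydroxypropylamino would test the chain with a hydroxyl in place of the methoxy.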